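The compounds below may be only part of what the source reports. "The series", "measured", "known", "first", "only" and "open" are said of these compounds alone.

Measured so far:
compound 1 `Cc1c(CO)c(CO)c2n1[C@@H](c1ccccc1)SC2` — 600 nM
compound 2 `OCc1c(CO)c(-c2ccccc2)n2c1CS[C@@H]2c1ccccc1` — 70200 nM

Among the compounds with values here, in a functional assay on MCF7 cells (Homo sapiens) for cytotoxicity, read by MTT assay, with a stated time of 96 h (a higher number here means a weaker inhibitor, a lower number a stronger inhibitor), compound 2 stands highest of the two numbers; its nearest neighbour is compound 1, and the single measured step, a 120-fold higher number from compound 1 to compound 2 (2.07 log units; beyond the scatter), is large. Compound 3 `OCc1c(CO)c(-c2ccc(F)cc2)n2c1CS[C@@H]2c1ccccc1` differs from compound 2 by fluoro in place of hydrogen on an aromatic carbon. Within the data shown here, no measured step bears on this change; the one step known concerns another group on the shared core and gives no direction for it. The expected step in this assay is therefore none beyond the scatter, a 1.0-fold lower number from compound 2 to compound 3 (0.00 log units; within the scatter). Compound 3 is estimated at 70000 nM, within 25000 nM to 200000 nM.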

Compound 3, half-maximal inhibitory concentration: 26400 nM
For compound 3 the middle estimate is 2.7-fold (0.42 log units) above the measured one; the measured number falls inside the stated range.
By their numbers in this assay, from the lowest: compound 1; then compound 3; then compound 2.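

Fluoro in place of hydrogen gives a 2.7-fold lower number from compound 2 to compound 3 (0.42 log units; beyond the scatter) in this assay and shows that the phenyl group at this position responds to a single added atom. Against methyl, 4-fluorophenyl still gives a 44-fold higher number from compound 1 to compound 3 (1.64 log units; beyond the scatter) and so recovers only part of the loss seen with phenyl. Nothing on hand explains the fluoro step. As far as these compounds go, whether chloro, methoxy or an amine at the same place on the phenyl would move the number further remains open. So does whether ethyl in place of methyl would keep the standing of compound 1.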